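The source may report more compounds than this note shows. Statements on the series, on what has been measured and on what is new or still open speak of the compounds shown alone.

Compound 3 `C#Cc1cc(C(O)Cc2ccccc2)c2cn[nH]c2c1` gives the highest number of the three compounds measured in an assay for binding affinity to Indoleamine 2,3-dioxygenase 1 (Homo sapiens), read by spectrophotometry, with a stated time of 30 min (on this read-out lower numbers stand for tighter binding and higher numbers for weaker binding), namely 1300 nM. Compound 1 `Cc1cc(C(O)Cc2ccccc2)c2cn[nH]c2c1` gives 470 nM in this assay, and compound 2 `OC(Cc1ccccc1)c1cc(Br)cc2[nH]ncc12` gives 140 nM. The steps of a 2.8-fold higher number from compound 1 to compound 3 (0.44 log units; beyond the scatter) and a 9.3-fold higher number from compound 2 to compound 3 (0.97 log units; beyond the scatter) show that changing the group at this position moves the number by modest amounts. Compound 4 `CCc1cc(C(O)Cc2ccccc2)c2cn[nH]c2c1` differs from compound 3 by ethyl in place of ethynyl on an aromatic carbon. Within the data shown here, no measured step swaps ethynyl for ethyl, so the nearest guide is the methyl analogue, compound 1, whose value of 470 nM in this assay was reached from compound 3 by reversing the step of a 2.8-fold higher number from compound 1 to compound 3 (0.44 log units; beyond the scatter). Compound 4 is therefore expected to show a lower number than compound 3, a step of about a 2.6-fold lower number from compound 3 to compound 4 (0.41 log units; beyond the scatter). The estimate for compound 4 is 500 nM, within a range of 150 nM to 1600 nM.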

Compound 4, dissociation constant: 740 nM
Compound 4: the middle estimate sits 1.5-fold (0.17 log units) below what was measured, within the range that was stated.
By their numbers in this assay, from the lowest: compound 2; then compounds 1, 4 and 3 (each within the scatter of the next, the first and the last beyond it).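

In this assay, ethyl in place of ethynyl gives a 1.8-fold lower number from compound 3 to compound 4 (0.24 log units; within the scatter), and ethyl in place of methyl gives a 1.6-fold higher number from compound 1 to compound 4 (0.20 log units; within the scatter); both steps lie within the scatter, so ethyl cannot be told apart from either group. Ethyl in place of bromo gives a 5.3-fold higher number from compound 2 to compound 4 (0.72 log units; beyond the scatter), beyond the scatter, so bromo now stands apart from all three carbon groups at this position. No measurement here bears on what sets bromo apart. Still open, from the compounds shown here alone, is whether chloro, iodo, a propyl chain or an amine on this aromatic carbon would match bromo or fall with the carbon groups.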